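The source may hold more compounds than are shown below. What is called first, only, known or untested is meant among the compounds shown, and "the series" means these compounds.

Three compounds share one core and were all tested in a functional assay on NPC-TW01 cells (Homo sapiens) for antiproliferative activity, read by MTT assay, with a stated time of 72 h; on this read-out lower numbers stand for stronger inhibition of growth and higher numbers for weaker inhibition of growth. Compound 1 `O=C(COc1c(-c2ccccc2)oc2ccccc2c1=O)Nc1ccc2ccccc2c1` gives 6520 nM in this assay. Compound 2 `O=C(COc1ccc2oc(-c3ccccc3)cc(=O)c2c1)Nc1ccc2ccccc2c1` gives 6750 nM in this assay, a number so close to that of compound 1 that the two cannot be told apart. Compound 3 `O=C(COc1ccc2c(=O)c(-c3ccccc3)coc2c1)Nc1ccc2ccccc2c1` gives 1370 nM in this assay, a lower number than either of the others, and its gap to compound 1 is wider than repeated measurements would produce. On these three numbers compound 1 therefore stands on the weaker side, with compound 3 the only one that clearly inhibits growth more strongly.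

Compound 4 `O=C(COc1c(-c2ccccc2)oc2ccccc2c1=O)Nc1ccc(F)cc1` keeps the core of compound 1 and changes only the group on the amide nitrogen: 4-fluorophenyl in place of naphthalen-2-yl on an amide-type nitrogen. For the measured compounds named here, no pair among the measured compounds shows what such a swap does, so nothing measured points to a direction. The working expectation is a change no larger than the usual scatter of this assay, with the number for compound 4 perhaps drifting upward, towards weaker inhibition, rather than downward. The estimate for compound 4 is therefore 8000 nM, with a range from 3000 nM to 25000 nM. The step of a 1.2-fold higher number from compound 1 to compound 4 (0.09 log units; within the scatter) is expected to be small.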

Compound 4, concentration for 50% growth inhibition: 9500 nM
Beside the measured number, compound 4's estimate is 1.2-fold (0.07 log units) below it; measured number inside the range.
By their numbers in this assay, from the lowest: compound 3; then compounds 1, 2 and 4 (each within the scatter of the next).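

In this assay, for the compounds shown here, the swap of naphthalen-2-yl for 4-fluorophenyl on the amide-type nitrogen gives a 1.5-fold higher number from compound 1 to compound 4 (0.16 log units; within the scatter), the first reading of a change at this position with the rest of the molecule held fixed. On the core of compound 1, then, a group with two aromatic rings of carbon can give way to a smaller group with one such ring and a fluorine, without a difference that can be told from the ordinary scatter of repeated measurements. Nothing measured here explains why the two groups read alike.

From the compounds shown here alone, this single pair speaks only for the arrangement in compound 1, so it remains open whether the same swap would read alike in compound 2 or compound 3, where the chain and the phenyl group sit differently. Also open, going by these compounds, is what a group of another kind on the amide nitrogen would do, such as a plain butyl chain, a phenyl ring carrying an amine, or a phenyl ring carrying a carboxylic acid.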